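Ethoxy in place of hydrogen on the benzylidene ring

This account rests on a few compounds, and the source may have more. Where it says the series, first, only, none or still open, it means among the compounds named here.

Compound 1 `C=CCOc1c(C)c(C)c2c(c1C)CCC(C)(COc1ccc(/C=C3\SC(=O)NC3=O)cc1)O2` gives the lowest number of the three measured compounds in a functional assay on MCF7 cells (Homo sapiens), tested at 2.5 uM (on this read-out higher numbers stand for a weaker effect at the one concentration tested and lower numbers for a stronger effect), at 45%. Compound 2 `CC(C)=CCOc1c(C)c(C)c2c(c1C)CCC(C)(COc1ccc(/C=C3\SC(=O)NC3=O)cc1F)O2` gives 95% in this assay, and compound 3 `CC(C)=CCOc1c(C)c(C)c2c(c1C)CCC(C)(COc1ccc(/C=C3\SC(=O)NC3=O)cc1C)O2` gives 89%, so both stand well above compound 1. Among the compounds with values here, the one single-point step among them, a number 6 percentage points lower from compound 2 to compound 3 (within the scatter), shows that methyl in place of fluoro on an aromatic carbon changes little. Compound 4 `C=CCOc1c(C)c(C)c2c(c1C)CCC(C)(COc1ccc(/C=C3\SC(=O)NC3=O)cc1OCC)O2` differs from compound 1 by ethoxy in place of hydrogen on an aromatic carbon; the new ethoxy sits on an aromatic carbon of a six-membered aromatic ring of carbon only, ortho to a large group. Within the data shown here, no measured step introduces a group onto that ring in place of hydrogen of compound 1, and compounds 2 and 3 differ from compound 1 in two places at once, so they cannot isolate the effect of the new group. The step from compound 2 to compound 3 suggests that the identity of a small group on this ring matters little, but it does not show what adding one does. Compound 4 is therefore expected to give a number somewhat higher than compound 1, by a number 20 percentage points higher from compound 1 to compound 4 (beyond the scatter), with wide uncertainty, so that compound 4 is estimated at 65% in this assay, between 35% and 95%.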

Compound 4, a percentage reported as activity, at one concentration (the size of the read-out at that concentration, not a potency): 107%
Compound 4: middle estimate off by 42 percentage points, on the low side; measured number outside the range, above it.
By their numbers in this assay, from the lowest: compound 1; then compounds 3 and 2 (each within the scatter of the next); then compound 4.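

Within the series of compound 1, ethoxy in place of hydrogen on an aromatic carbon, ortho to a large group, gives a number 62 percentage points higher from compound 1 to compound 4 (beyond the scatter) in this assay and so removes the stronger effect that compound 1 shows at the one concentration tested. The earlier step, a number 6 percentage points lower from compound 2 to compound 3 (within the scatter), showed only that methyl and fluoro read alike at their place on this ring, whereas this step shows that a group entering in place of hydrogen can change the read-out a great deal, at least when that group is ethoxy. Nothing given here accounts for the size of this step.

On these data alone, what remains open is whether the loss belongs to ethoxy alone or to any group at this position, since the series of compound 1 offers no smaller group, such as fluoro, methyl or methoxy, in place of the same hydrogen. As far as these compounds go, it is also open how a hydroxy group, an amine or a longer alkoxy chain would read here, and whether ethoxy would give a step of similar size on a core other than that of compound 1.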